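The source may hold more compounds than are shown below. What is called first, only, known or untested is meant among the compounds shown, and "the series" means these compounds.

Working notes on the series. Among the compounds with values here, compound 3 `O=C(Nc1ccc(Cl)c(-c2nnc3c(Cl)cccn23)c1)c1cccc(Cl)c1` is the one member with a number rather than a limit: in a functional assay on AN3-CA cells (Homo sapiens) for antiproliferative activity, read by MTT assay, with a stated time of 72 h (on this read-out lower numbers stand for stronger inhibition and higher numbers for weaker inhibition), compound 3 gives 68400 nM. Compound 1 `O=C(Nc1ccc(Cl)c(-c2nnc3c(Cl)cccn23)c1)c1ccc(C(F)(F)F)cc1Cl` reaches only a limit of the assay, > 100000 nM in this assay. Compound 2 `Cc1nc(C(=O)Nc2ccc(Cl)c(-c3nnc4c(Cl)cccn34)c2)cs1` likewise gives only a limit, > 100000 nM. Within the data shown here, the single step between measured compounds is an at least 1.4-fold lower number from compound 2 to compound 3 (0.16 log units; that floor lies within the scatter); its floor lies within the scatter, and the series is dominated by the limit of > 100000 nM in this assay, at which 2 of the 3 values shown sit, so little is pinned down.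

Compound 4 `O=C(Nc1ccc(Cl)c(-c2nnc3c(Cl)cccn23)c1)c1ccon1` has not been measured. It differs from compound 3 by 1,2-oxazol-3-yl in place of 3-chlorophenyl on a carbonyl carbon. Among the measured compounds shown here, the incoming 1,2-oxazol-3-yl is a heteroaryl of the same five-membered kind as the 2-methyl-1,3-thiazol-4-yl of compound 2, which gave only a limit, whereas 3-chlorophenyl on compound 3 gave the sole number. A move toward a higher number is therefore expected in this assay, with a fair chance of a limit. The expected step from compound 3 to compound 4 is a 2.2-fold higher number from compound 3 to compound 4 (0.34 log units; beyond the scatter). Compound 4 is estimated at 150000 nM, within 40000 nM to 600000 nM.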

Compound 4, half-maximal inhibitory concentration: > 100000 nM
Compound 4 ended at the assay's limit; the forecaster's own chance of this, stated with the estimate: 70%; the middle value does not contradict the limit.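

In this assay, going by these compounds, replacing 3-chlorophenyl with 1,2-oxazol-3-yl on a carbonyl carbon gives an at least 1.4-fold higher number from compound 3 to compound 4 (0.16 log units; that floor lies within the scatter); this is only a floor set by a limit, so the true size of the step remains unknown. Compound 4 now stands with compound 2, so both five-membered heteroaryl groups shown end at a limit, while 3-chlorophenyl on compound 3 alone gives a number, although the six-membered aromatic ring of compound 1 goes against any simple ring-size reading by also ending at a limit. The step between compound 2 and compound 4 cannot be read, and the series remains tied to a single limit: the limit of > 100000 nM in this assay, at which 3 of the 4 values shown sit.

On these data alone, whether plain phenyl without the chlorine, or a saturated amine such as piperidine on the carbonyl carbon, would give a number remains open. Within the data shown here, with compound 3 at 68400 nM as the only number, no ranking of groups at this position can be drawn.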